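The compounds below may be only part of what the source reports. "The series", "measured", "known", "first", "only" and "open" are said of these compounds alone.

Working notes on the series in a functional assay on A549 cells (Homo sapiens) for cytotoxicity, read by MTT assay, with a stated time of 72 h; a higher number here means a weaker inhibitor, a lower number a stronger inhibitor. Here compound 1 `Cc1cc(=O)n(-c2ccccc2OC(F)(F)F)nc1C(=O)Nc1ccc(Oc2ncnc3c2ccn3C)c(F)c1`, with 2-(trifluoromethoxy)phenyl on an aromatic nitrogen, gives > 60000 nM, a limit of the assay. Compound 2 `Cc1cc(=O)n(-c2cccc(F)c2)nc1C(=O)Nc1ccc(Oc2ncnc3c2ccn3C)c(F)c1` gives > 60000 nM, also a limit, so compound 2 has no number of its own. The next change leads to compound 3 `Cc1cc(=O)n(-c2ccccc2C(F)(F)F)nc1C(=O)Nc1ccc(Oc2ncnc3c2ccn3C)c(F)c1`: 2-(trifluoromethyl)phenyl in place of 3-fluorophenyl on an aromatic nitrogen. In words, 2-(trifluoromethyl)phenyl stands in place of 3-fluorophenyl on an aromatic nitrogen. Among the compounds with values here, the one measured step bearing on this change is a step that the two limits leave unreadable from compound 1 to compound 2, and its size cannot be read. Given (the limit of > 60000 nM in this assay, at which 2 of the 2 values shown sit), no step beyond the scatter is expected in this assay, and no direction can be assigned. The expected move is a number no higher from compound 2 to compound 3 (the limit leaves the size open). A further limit is the likeliest report for compound 3. For compound 3 the estimated value is 60000 nM, with an expected range of 25000 nM to 100000 nM.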

Compound 3, half-maximal inhibitory concentration: 35400 nM
For compound 3 the middle estimate is 1.7-fold (0.23 log units) above the measured one, within the range that was stated.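

In this assay, within the data shown here, compound 3 is the only one of the three compounds to give a number rather than a limit, so the aryl group on the aromatic nitrogen can be carried with a readable value. Replacing 3-fluorophenyl with 2-(trifluoromethyl)phenyl gives an at least 1.6-fold lower number from compound 2 to compound 3 (0.22 log units; that floor lies within the scatter), and trifluoromethyl in place of trifluoromethoxy on an aromatic carbon gives an at least 1.6-fold lower number from compound 1 to compound 3 (0.22 log units; that floor lies within the scatter), so neither change is shown to exceed the scatter. Both steps remain floors, with their true size open: the limit of > 60000 nM in this assay, at which 2 of the 3 values shown sit.

Going by these compounds, whether an amine or a carboxylic acid on this phenyl ring, or a phenyl with no substituent, would give a clearly lower number stays open. On these data alone, the size of the step between compound 1 and compound 2 also stays open, since their two limits leave it unreadable.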